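From 4-fluorophenyl to 2,6-difluorophenyl on a shared core

The source may report more compounds than this note shows. Statements on the series, on what has been measured and on what is new or still open speak of the compounds shown alone.

In a functional assay with Homo sapiens as the target (on this read-out lower numbers stand for stronger inhibition and higher numbers for weaker inhibition), compound 1 `CC(C)[C@H](NC(=O)COc1cccc2ccccc12)C(=O)N[C@@H](CC(=O)O)C(=O)COc1ccccc1` gives 11200 nM and compound 2 `CC(C)[C@H](NC(=O)COc1cccc2ccccc12)C(=O)N[C@@H](CC(=O)O)C(=O)COc1cccc2ccccc12` gives 19000 nM while compound 3 `CC(C)[C@H](NC(=O)COc1cccc2ccccc12)C(=O)N[C@@H](CC(=O)O)C(=O)COc1ccc(F)cc1` gives 14300 nM and so sits within the scatter of both others. Compound 4 `CC(C)[C@H](NC(=O)COc1cccc2ccccc12)C(=O)N[C@@H](CC(=O)O)C(=O)COc1c(F)cccc1F` is still unmeasured. It carries one change from compound 3 as 2,6-difluorophenyl in place of 4-fluorophenyl on an oxygen on a saturated carbon with 2,6-difluorophenyl in place of 4-fluorophenyl on an oxygen on a saturated carbon.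

Among the compounds with values here, three measured steps bear on this change. The step of a 1.3-fold higher number from compound 1 to compound 3 (0.11 log units; within the scatter) put fluoro in place of hydrogen on an aromatic carbon. The step of a 1.7-fold higher number from compound 1 to compound 2 (0.23 log units; within the scatter) put naphthalen-1-yl in place of phenyl on that same oxygen, and the step of a 1.3-fold lower number from compound 2 to compound 3 (0.12 log units; within the scatter) put 4-fluorophenyl in place of naphthalen-1-yl there. All three stay within the scatter. Within the data shown here, no measured compound yet carries 2,6-difluorophenyl, so the expectation is uncertain, but no step beyond the scatter is expected. The expected step is a 1.2-fold lower number from compound 3 to compound 4 (0.08 log units; within the scatter) on this evidence. The estimate for compound 4 is 12000 nM with an expected range from 5000 nM to 28000 nM once it is measured.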

Compound 4, half-maximal inhibitory concentration: > 100000 nM
Compound 4: no number, only a limit (the forecaster's own chance of this, stated with the estimate: 5%); middle value at least 8.3-fold (0.92 log units) away from the limit.
By their numbers in this assay, from the lowest: compounds 1, 3 and 2 (each within the scatter of the next). At a limit, above all of these: compound 4.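

In this assay compound 4 gives only a limit of the assay, not a number: the limit of > 100000 nM in this assay, at which 1 of the 4 values shown sits. Phenyl, 4-fluorophenyl and naphthalen-1-yl on this oxygen had all stayed within the scatter of one another, yet 2,6-difluorophenyl brings an at least 6.9-fold higher number from compound 3 to compound 4 (0.84 log units; beyond the scatter), an at least 5.2-fold higher number from compound 2 to compound 4 (0.72 log units; beyond the scatter) and an at least 8.9-fold higher number from compound 1 to compound 4 (0.95 log units; beyond the scatter), so the group at this position can matter after all. Compound 3 also carries a fluoro and stays within the scatter of compound 1, so a fluoro on this ring is not by itself enough for such a step.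

The compounds shown do not tell why 2,6-difluorophenyl behaves so differently. They also leave open whether the same step would follow with chlorine or methyl in place of the two fluorines.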